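Thiophen-2-yl replaces acetyl on the shared core

The compounds below may be only part of what the source reports. "The series", "measured", "known", "first", "only" and "open" are said of these compounds alone.

In a functional assay on HeLa cells (Homo sapiens) for cytotoxicity (on this read-out lower numbers stand for stronger inhibition and higher numbers for weaker inhibition), compound 1 (`COc1ccc2c(c1)C(=O)C=CC2=O`) gives 22700 nM and compound 2 (`CC(=O)Oc1ccc2c(c1)C(=O)C=CC2=O`) gives 27700 nM as its reading, so the two stand level. Compound 3 (`O=C1C=CC(=O)c2cc(Oc3cccs3)ccc21`) carries thiophen-2-yl in place of acetyl on an oxygen on an aromatic ring. Going by the values given here, the only measured step at that oxygen, from compound 1 to compound 2, is a 1.2-fold higher number from compound 1 to compound 2 (0.09 log units; within the scatter) and it involves no ring, so it is a thin guide. No change beyond the scatter is expected. The estimated step is a 1.5-fold lower number from compound 2 to compound 3 (0.19 log units; within the scatter) in this read-out. Compound 3 is therefore expected near 18000 nM (range 6000 nM to 45000 nM).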

Compound 3, half-maximal inhibitory concentration: 8860 nM
Beside the measured number, compound 3's estimate is 2.0-fold (0.31 log units) above it, and the stated range covers the measured number.
By their numbers in this assay, from the lowest: compound 3; then compounds 1 and 2 (each within the scatter of the next).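

At this oxygen on an aromatic ring, swapping methyl for acetyl had stayed within the scatter, but thiophen-2-yl moves the number beyond it: in this assay there is a 3.1-fold lower number from compound 2 to compound 3 (0.50 log units; beyond the scatter), and likewise a 2.6-fold lower number from compound 1 to compound 3 (0.41 log units; beyond the scatter). Both steps are modest, yet they show that this position does respond to the group it carries. The data at hand give no explanation for this. Going by these compounds alone, with only one ring group at this oxygen, it remains open whether a phenyl ring would do the same, or whether the sulfur-containing thiophene matters.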